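This account rests on a few compounds, and the source may have more. Where it says the series, first, only, none or still open, it means among the compounds named here.

So far two compounds with the same core have been measured. In a functional assay on A549 cells (Homo sapiens) for antiproliferative activity, read by MTT assay, with a stated time of 48 h (on this read-out higher numbers stand for weaker inhibition of growth and lower numbers for stronger inhibition of growth), compound 1 `COC(=O)N1N=C(c2ccccc2)CC1c1cc(OC)c(OC)c(OC)c1` gives 2880 nM and compound 2 `CCOc1cccc(C2=NN(C(=O)OC)C(c3cc(OC)c(OC)c(OC)c3)C2)c1` gives 5290 nM. Among the compounds with values here, these two values lie within the scatter of each other, so compound 2 stands level with the only other measured compound, and no order can be read between them. The next compound, compound 3 `COC(=O)N1N=C(c2ccc(O)cc2)CC1c1cc(OC)c(OC)c(OC)c1`, departs from compound 2 on the carbon with a double bond to nitrogen: 4-hydroxyphenyl in place of 3-ethoxyphenyl on a carbon with a double bond to nitrogen. Within the data shown here, only one measured step bears on this exchange, ethoxy in place of hydrogen on an aromatic carbon, which gave a 1.8-fold higher number from compound 1 to compound 2 (0.26 log units; within the scatter). Neither measured compound carries a 4-hydroxyphenyl, so the data offer no direct evidence on that group. Given the size of the step to compound 2, no step beyond the scatter is expected in this assay, with only a slight lean toward a lower number. The estimated step is a 1.5-fold lower number from compound 2 to compound 3 (0.18 log units; within the scatter). For compound 3 the expected value is 3500 nM, with an estimated range from 1200 nM to 10000 nM.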

Compound 3, concentration for 50% growth inhibition: 8570 nM
The estimate for compound 3 lay 2.4-fold (0.39 log units) below the measured number; the range from low to high includes it.
By their numbers in this assay, from the lowest: compounds 1, 2 and 3 (each within the scatter of the next, the first and the last beyond it).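

In this assay, within the data shown here, hydroxy in place of hydrogen on the phenyl group of compound 1 gives the first step that lies beyond the scatter (a 3.0-fold higher number from compound 1 to compound 3 (0.47 log units; beyond the scatter)), so the aromatic group on the carbon with a double bond to nitrogen does respond to a change, though only modestly. The direct exchange of 3-ethoxyphenyl for 4-hydroxyphenyl stays within the scatter (a 1.6-fold higher number from compound 2 to compound 3 (0.21 log units; within the scatter)), so these two groups cannot be told apart in this assay, and neither compound 2 nor compound 3 can be placed ahead of the other. No measurement at hand explains the response at this position.

The ethoxy and hydroxy groups stand at different places on the phenyl ring, so 3-hydroxyphenyl and 4-ethoxyphenyl would be needed to separate the effect of the group from that of its place. Going by these compounds, it also remains open whether an amine, a carboxylic acid or a longer alkoxy chain on this ring would move the number further, and in which direction.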